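Dichlorophenyl Variant of a Weak Chemokine Receptor Binder

The source may hold more compounds than are shown below. What is called first, only, known or untested is meant among the compounds shown, and "the series" means these compounds.

Compound 3 `CN(CC1=CC[C@H]2C[C@@H]1C2(C)C)Cc1ccc(-c2cccc(O)c2)cc1` carries a 3-hydroxyphenyl group on the shared core. In an assay on HEK293 cells for displacement of a labelled ligand from C-X-C chemokine receptor type 3 (Homo sapiens) (a higher number here means a weaker inhibitor, a lower number a stronger inhibitor), compound 3 gives > 316 nM, which is a limit of the assay and not a number. Its closest relatives are compound 1 `CN(CC1=CC[C@H]2C[C@@H]1C2(C)C)Cc1ccc(-c2cccc(F)c2)cc1`, with a 3-fluorophenyl group, and compound 2 `CN(CC1=CC[C@H]2C[C@@H]1C2(C)C)Cc1ccc(-c2ccccc2F)cc1`, with a 2-fluorophenyl group. In this assay compound 1 gives 2510 nM, a weak result. In this assay compound 2 gives > 316 nM, again a limit of the assay. Owing to the limit of > 316 nM in this assay, at which 2 of the 3 values shown sit, none of the steps among these three can be read: a step that the limit leaves unreadable from compound 1 to compound 2, a step that the limit leaves unreadable from compound 1 to compound 3 and a step that the two limits leave unreadable from compound 2 to compound 3. So compound 3 stands only as "weaker than the threshold", alongside compound 2, while compound 1 is the only one with a number.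

Compound 4 `CN(CC1=CC[C@H]2C[C@@H]1C2(C)C)Cc1ccc(-c2cc(Cl)cc(Cl)c2)cc1` differs from compound 3 by 3,5-dichlorophenyl in place of 3-hydroxyphenyl on an aromatic carbon. Among the measured compounds shown here, no measured step bears directly on this exchange; the only firm point of reference is the weak number of compound 1. The step is therefore expected to be a step that the limit leaves unreadable from compound 3 to compound 4, with no reason to expect a move beyond the scatter in either direction. For compound 4 the estimate in this assay is 1500 nM, within a range from 300 nM to 8000 nM.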

Compound 4, inhibition constant: > 316 nM
Compound 4 gave a limit, no number; the forecaster's own chance of this, stated with the estimate: 50%; the middle value lies beyond the limit too.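

Among the compounds shown here, compound 4 also ends at a limit of the assay and not at a number, so no step linking it to compound 1, compound 2 or compound 3 can be read, because the readings stop at a shared threshold: the limit of > 316 nM in this assay, at which 3 of the 4 values shown sit.

Left open is how compound 2, compound 3 and compound 4 compare with one another and with compound 1, the only compound here with a number.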